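The source may hold more compounds than are shown below. What is called first, only, known or untested is meant among the compounds shown, and "the series" means these compounds.

In a functional assay on CEM-DNR-bulk cells (Homo sapiens), read by MTT assay, with a stated time of 72 h (a higher number here means a weaker inhibitor, a lower number a stronger inhibitor), compound 3 `C#Cc1cn([C@@H]2O[C@H](CO)[C@@H](O)[C@H]2O)c2ncnc(N(C)C)c12` gives 240 nM, the lowest of the two numbers shown; the nearest is compound 1 `C#Cc1cn([C@@H]2O[C@H](CO)[C@@H](O)[C@H]2O)c2ncnc(OC)c12`, which gives 3490 nM. Going by the values given here, the single step between them, a 15-fold lower number from compound 1 to compound 3 (1.16 log units; beyond the scatter), concerns a group on an aromatic carbon of the shared core. Compound 2 `O=c1[nH]cnc2c1c(-c1ccsc1)cn2[C@@H]1O[C@H](CO)[C@@H](O)[C@H]1O` returns only a limit, > 20000 nM, which is the limit of > 20000 nM in this assay, at which 1 of the 3 values shown sits. Compound 4 `CN(C)c1ncnc2c1c(-c1ccsc1)cn2[C@@H]1O[C@H](CO)[C@@H](O)[C@H]1O` keeps the dimethylamino of compound 3 and differs from it by thiophen-3-yl in place of ethynyl on an aromatic carbon. Among the compounds with values here, no measured step covers this change; compound 2 carries the same thiophen-3-yl but differs from compound 1 in two places, so its limit cannot be assigned to either. The expected step of a 5.0-fold higher number from compound 3 to compound 4 (0.70 log units; beyond the scatter) is therefore toward a weaker inhibitor, of uncertain size. Compound 4 is estimated at 1200 nM, within 200 nM to 10000 nM.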

Compound 4, half-maximal inhibitory concentration: > 20000 nM
Compound 4 gave a limit, no number; the forecaster's own chance of this, stated with the estimate: 20%; middle value at least 16-fold (1.22 log units) from the limit.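

In this assay, going by these compounds alone, thiophen-3-yl in place of ethynyl gives an at least 83-fold higher number from compound 3 to compound 4 (1.92 log units; beyond the scatter), so this carbon on the five-membered aromatic ring tolerates the change poorly, which the earlier compounds could not show. The value of compound 4 is a limit, so the step has only a lower bound. Dimethylamino, the group behind a 15-fold lower number from compound 1 to compound 3 (1.16 log units; beyond the scatter), does not lift thiophen-3-yl off the limit, where compound 2 and compound 4 both sit: the limit of > 20000 nM in this assay, at which 2 of the 4 values shown sit.

On these data alone, whether ethynyl is special here stays open. A methyl group, a bromine atom or a longer alkyne chain on this carbon would test that.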